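Thiophen-2-yl for ethyl: little change expected in cytotoxicity

The compounds below may be only part of what the source reports. "The series", "measured", "known", "first", "only" and "open" are said of these compounds alone.

compound 1 `CCC[S+]([O-])CCCCN=C=S` gives 3910 nM
compound 2 `[O-][S+](CCCCN=C=S)c1ccccc1` gives 6340 nM
compound 3 `[O-][S+](CCCCN=C=S)Cc1ccccc1` gives 2850 nM

In a functional assay on HepG2 cells (Homo sapiens) for cytotoxicity, read by MTT assay, with a stated time of 72 h (a lower number here means a stronger inhibitor, a higher number a weaker inhibitor), compound 1 lies within the scatter of both compound 2 and compound 3. Compound 4 `[O-][S+](CCCCN=C=S)Cc1cccs1` is still unmeasured. It differs from compound 1 as follows: thiophen-2-yl in place of ethyl on a saturated chain carbon bound to a sulfur with thiophen-2-yl in place of ethyl on a saturated chain carbon bound to a sulfur. Among the measured compounds shown here, no pair of measured compounds isolates this change. The nearest guide is compound 3 at 2850 nM as it also carries a ring at that place. A small fall in the number is expected, not beyond the scatter, the estimated step being a 1.3-fold lower number from compound 1 to compound 4 (0.10 log units; within the scatter) in this assay overall. Compound 4 is expected at 3100 nM with 1400 nM to 6800 nM as its estimated range.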

Compound 4, half-maximal inhibitory concentration: 3820 nM
Beside the measured number, compound 4's estimate is 1.2-fold (0.09 log units) below it; the measured number falls inside the stated range.
By their numbers in this assay, from the lowest: compounds 3, 4, 1 and 2 (each within the scatter of the next, the first and the last beyond it).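

In this assay, thiophen-2-yl in place of ethyl on a saturated chain carbon bound to a sulfur gives a 1.0-fold lower number from compound 1 to compound 4 (0.01 log units; within the scatter). This is the first step among these compounds that isolates a single change at this place, and it shows that a five-membered aromatic ring can enter there with the number staying within the scatter of compound 1. No measurement shown accounts for this result.

As far as these compounds go, whether an amine or a carboxylic acid at this place would move the number beyond the scatter remains open.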